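A five-membered amide-bearing ring replaces fluoro on compound 1

A few compounds are considered here, and "the series" means these few. Any claim that something is new, unique, unknown or untested is made for them only; others in the source may bear on it.

Compound 1 `COc1c(F)c(F)cc2c(=O)c(C(=O)O)cn(Cc3ccc(-c4ccccc4)cc3)c12` was examined in an assay on isolated protein for inhibition of DNA topoisomerase 1 (Homo sapiens), with a stated time of 15 min, tested at 200 uM (on this read-out higher numbers stand for more inhibition at the one concentration tested (going by the name of the read-out) and lower numbers for less inhibition), where compound 1 was reported as "not active" (no number reported) without any number attached. On the numbers shown, compound 1 therefore stands nowhere: it has no value of its own to compare, only the statement that it did not inhibit. Two related compounds did give numbers. Compound 2 `COc1c(N2CC[C@@H](CN)C2)c(F)cc2c(=O)c(C(=O)O)cn(Cc3ccc(-n4cccn4)cc3)c12` gives 10% in this assay, and compound 3 `O=C(O)c1cn(Cc2ccc(-n3cccn3)cc2)c2cc(NC[C@@H]3CCNC3)c(F)cc2c1=O` gives 10% in this assay; these two values lie within the scatter of one another, so nothing separates them. Compound 4 `COc1c(N2CC[C@@H](C(N)=O)C2)c(F)cc2c(=O)c(C(=O)O)cn(Cc3ccc(-c4ccccc4)cc3)c12` has not yet been tested. It differs from compound 1 in one place: 3-carbamoylpyrrolidin-1-yl in place of fluoro on an aromatic carbon. Among the measured compounds shown here, no step between measured compounds is known here, so the size of the move from compound 1 to compound 4 cannot be read from a precedent; the expectation is for no change beyond the scatter, with a low number at most. Compound 4 is expected to give about 10% in this assay, between 0% and 25%. For the measured compounds named here, that expectation rests on compound 2 at 10% and compound 3 at 10%, the only numbers in hand.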

Compound 4, a percentage reported as inhibition, at one concentration (the size of the read-out at that concentration, not a potency): 10%
Estimate against measurement, compound 4: no gap at the digits printed; the measured number falls inside the stated range.
By their numbers in this assay, from the lowest: compounds 2, 3 and 4 (each within the scatter of the next).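

Among the compounds shown here, no step from compound 1 to compound 4 can be read in this assay, as compound 1 carries no number there. The compounds shown leave open what 3-carbamoylpyrrolidin-1-yl in place of fluoro does to inhibition. No supporting measurement bears on this result.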